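This account rests on a few compounds, and the source may have more. Where it says the series, first, only, none or still open, it means among the compounds named here.

Measured so far:
- compound 3, `COc1ccc(F)cc1S(=O)(=O)Nc1cncc(C(N)=O)c1`: 109 nM
- compound 1, `COc1ccc(Cl)cc1S(=O)(=O)Nc1cncc(C(=O)Nc2ccccc2)c1`: "not determined" (no result reported)
- compound 2, `COc1ccc(Cl)cc1S(=O)(=O)Nc1cncc(-c2ccccc2C)c1`: "not determined" (no result reported)

For the measured compounds named here, in an assay on isolated protein for inhibition of alkaline phosphatase, tissue-nonspecific isozyme (Homo sapiens) (on this read-out lower numbers stand for stronger inhibition and higher numbers for weaker inhibition), compound 3 gives 109 nM and is the only compound of the three with a number; for compound 1 and compound 2 no result was reported, so they give no reference point. Compound 4, `COc1ccc(Cl)cc1S(=O)(=O)Nc1cncc(C(N)=O)c1`, is not yet measured. It differs from compound 3 by chloro in place of fluoro on an aromatic carbon. Going by the values given here, no step between two measured compounds exists in this set, so the size of the change cannot be read from the data. A swap of one halogen for another at the same place is expected to shift this assay little, likely within the scatter, with a slight lean towards stronger inhibition for compound 4. Compound 4 is therefore estimated at 80 nM, range 30 nM to 220 nM, meaning an expected step of a 1.4-fold lower number from compound 3 to compound 4 (0.13 log units; within the scatter).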

Compound 4, half-maximal inhibitory concentration: 105 nM
Estimate against measurement, compound 4: 1.3-fold (0.12 log units) below; low and high end bracket the measured number.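

In this assay, for the compounds shown here, chloro in place of fluoro, para to a methoxy group, gives a 1.0-fold lower number from compound 3 to compound 4 (0.02 log units; within the scatter) and so provides the first readable step: at this position, these two halogens cannot be told apart. No measured property bears on this result. Going by these compounds, whether a non-halogen group at this place, such as an amine or a nitrile, would give a step beyond the scatter remains open. Also open, on these data alone, is how a carboxylic acid in place of the primary amide shared by compound 3 and compound 4 would read.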